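A Bromo for a Methyl in Compound 4

The source may hold more compounds than are shown below. What is called first, only, known or untested is meant among the compounds shown, and "the series" means these compounds.

Going by the values given here, in a functional assay on MCF7 cells (Homo sapiens) for inhibition, read by MTT assay, with a stated time of 48 h (on this read-out lower numbers stand for stronger inhibition and higher numbers for weaker inhibition), compound 3 `Cc1ccc(/C=C2\SC(=O)N(CC(=O)Nc3c(C)n(C)n(-c4ccccc4)c3=O)C2=O)cc1` gives 65500 nM, the highest of the three numbers so far. Compound 1 `Cc1c(NC(=O)NCCN2C(=O)S/C(=C\c3ccc([N+](=O)[O-])cc3)C2=O)c(=O)n(-c2ccccc2)n1C` gives 18600 nM, and compound 2 `COc1cc(/C=C2\SC(=O)N(CCNC(=O)Nc3c(C)n(C)n(-c4ccccc4)c3=O)C2=O)cc(OC)c1OC` gives 7580 nM. Compound 4 `Cc1c(NC(=O)CN2C(=O)S/C(=C\c3ccc(Br)cc3)C2=O)c(=O)n(-c2ccccc2)n1C` differs from compound 3 by one exchange: bromo in place of methyl on an aromatic carbon. Put another way, the 4-methylphenyl of compound 3 becomes 4-bromophenyl in compound 4. Among the compounds with values here, no measured step makes this exchange. The nearest guide is a 2.5-fold lower number from compound 1 to compound 2 (0.39 log units; beyond the scatter), a modest step between two very different aromatic groups, on a chain that compound 3 does not carry. A smaller change is therefore expected here, and the estimated 1.3-fold lower number from compound 3 to compound 4 (0.12 log units; within the scatter) stays within the scatter. For compound 4 the expected value is 50000 nM, within an estimated range of 16000 nM to 120000 nM.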

Compound 4, half-maximal inhibitory concentration: 24100 nM
Estimate against measurement, compound 4: 2.1-fold (0.32 log units) above; the measured number falls inside the stated range.
By their numbers in this assay, from the lowest: compound 2; then compounds 1 and 4 (each within the scatter of the next); then compound 3.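

In this assay, the exchange of methyl for bromo alone, on an aromatic carbon para to a large group, gives a 2.7-fold lower number from compound 3 to compound 4 (0.43 log units; beyond the scatter). The earlier step changed two very different aromatic groups, whereas this one shows that a single small exchange at this place can move the number beyond the scatter. Nothing given here accounts for this step. Going by these compounds, how chloro, fluoro or an amine would read in the same place remains open, as does whether bromo would give a similar step on the urea-bearing chain of compound 1 and compound 2.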